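The source may hold more compounds than are shown below. What is called first, only, known or untested is meant among the compounds shown, and "the series" means these compounds.

Measured compounds in an ADME assay on Vero cells (Chlorocebus sabaeus) for cytotoxicity, read by MTT assay, with a stated time of 72 h; a lower number here means a stronger inhibitor, a higher number a weaker inhibitor:

Compound 1 `CC(C)CNc1nc(=O)c2cc([N+](=O)[O-])cc([N+](=O)[O-])c2s1` has "not determined" (no result reported) in this assay.
Compound 2 `O=c1nc(NC2CC2)sc2c([N+](=O)[O-])cc(C(F)(F)F)cc12` sits at a limit of this assay, > 100000 nM.
Compound 3 `O=c1nc(NC2CCCC2)sc2c([N+](=O)[O-])cc(C(F)(F)F)cc12` likewise sits at a limit of this assay, > 100000 nM.

Compound 3 therefore stands only on a limit in this assay, and of the other two entries one is also a limit and one carries no number at all. Among the measured compounds shown here, the single step between measured compounds, a step that the two limits leave unreadable from compound 2 to compound 3, cannot be read in size, as both ends sit at the same limit, (the limit of > 100000 nM in this assay, at which 2 of the 3 values shown sit).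

Compound 4 `O=C(O)C1CCN(c2nc(=O)c3cc(C(F)(F)F)cc([N+](=O)[O-])c3s2)CC1` differs from compound 3 by 4-carboxypiperidin-1-yl in place of cyclopentylamino on an aromatic carbon. For the measured compounds named here, no measured step in this assay bears on this change with a readable size; the only comparable step, a step that the two limits leave unreadable from compound 2 to compound 3, is unreadable. On that basis compound 4 is expected to remain at the limit as well, with an estimate of 150000 nM and a range from 100000 nM to 1000000 nM. The step this estimate implies, a step that the limit leaves unreadable from compound 3 to compound 4, is expected to be none beyond the scatter.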

Compound 4, half-maximal inhibitory concentration: > 100000 nM
Compound 4: no number, only a limit; the forecaster's own chance of this, stated with the estimate: 85%; the middle value is on the limit's open side.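

Compound 4 gives only a limit in this assay, > 100000 nM, so no new step can be read from compound 2 or compound 3 to compound 4. The compounds shown leave open whether any change of this amino substituent shifts the read-out in this assay, with no single number among them.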